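The source may hold more compounds than are shown below. What is called first, only, known or untested is meant among the compounds shown, and "the series" means these compounds.

Of the compounds shown here, three sharing one core have been tested in an ADME assay on L02 cells (Homo sapiens) for antiproliferative activity, read by MTT assay, with a stated time of 48 h; a higher number here means a weaker inhibitor, a lower number a stronger inhibitor. Compound 1 `COc1ccc(-n2nncc2CN2C(=O)C3(C(C#N)=C(N)Oc4c(N)cc5nc6ccccc6nc5c43)c3ccccc32)cc1` carries a 4-methoxyphenyl on an aromatic nitrogen; in this assay compound 1 reaches only the limit of the assay, > 50000 nM. Compound 2 `CCOc1ccccc1-n1nncc1CN1C(=O)C2(C(C#N)=C(N)Oc3c(N)cc4nc5ccccc5nc4c32)c2ccccc21` bears a 2-ethoxyphenyl in place of that group; in this assay compound 2 likewise gives only the limit, > 50000 nM. Compound 3 `Cc1ccc(-n2nncc2CN2C(=O)C3(C(C#N)=C(N)Oc4c(N)cc5nc6ccccc6nc5c43)c3ccccc32)cc1Cl` carries a 3-chloro-4-methylphenyl; in this assay compound 3 also stops at the limit, > 50000 nM. Since every value sits at the limit, the steps a step that the two limits leave unreadable from compound 1 to compound 2, a step that the two limits leave unreadable from compound 1 to compound 3 and a step that the two limits leave unreadable from compound 2 to compound 3 cannot be sized. Compound 3 therefore stands where the others stand, at the limit of > 50000 nM in this assay, at which 3 of the 3 values shown sit.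

Compound 4 `N#CC1=C(N)Oc2c(N)cc3nc4ccccc4nc3c2C12C(=O)N(Cc1cnnn1-c1ccc([N+](=O)[O-])cc1[N+](=O)[O-])c1ccccc12` differs from compound 3 by 2,4-dinitrophenyl in place of 3-chloro-4-methylphenyl on an aromatic nitrogen. Within the data shown here, none of the measured steps bears readably on this change, because all of them sit at the limit of > 50000 nM in this assay, at which 3 of the 3 values shown sit; the only pattern so far is that exchanging the aryl group on the aromatic nitrogen has never brought a compound into the measurable range, and no compound goes against it. Compound 4 is therefore expected to remain at or beyond the limit, with an expected step that the limit leaves unreadable from compound 3 to compound 4 that is not beyond the scatter. The estimate for compound 4 in this assay is 80000 nM, between 30000 nM and 200000 nM.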

Compound 4, half-maximal inhibitory concentration: 22800 nM
The estimate for compound 4 lay 3.5-fold (0.55 log units) above the measured number; the whole stated range lies above it.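

In this assay, the aryl group on the aromatic nitrogen proves able to bring a compound into the measurable range: the exchange for 2,4-dinitrophenyl gives an at least 2.1-fold lower number from compound 3 to compound 4 (0.34 log units; beyond the scatter), an at least 2.1-fold lower number from compound 2 to compound 4 (0.34 log units; beyond the scatter) and an at least 2.1-fold lower number from compound 1 to compound 4 (0.34 log units; beyond the scatter). Compound 4 thus goes against the earlier pattern, in which no exchange of this aryl group left the limit, and it is the only compound shown that does. Each of these steps gives only a minimum size, since the other end of each is a limit and not a number: the limit of > 50000 nM in this assay, at which 3 of the 4 values shown sit.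

What the compounds shown leave open is whether a phenyl with a single nitro group, or an amine in place of the nitro groups, would also leave the limit. On these data alone, how far compound 1, compound 2 and compound 3 truly lie from compound 4 also stays open.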